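Swapping a Chlorophenylsulfanyl Arm for an Imidazole Ring

The source may hold more compounds than are shown below. What is called first, only, known or untested is meant among the compounds shown, and "the series" means these compounds.

For the measured compounds named here, in a functional assay for inhibition of sodium/hydrogen exchanger (Oryctolagus cuniculus) (on this read-out higher numbers stand for weaker inhibition and lower numbers for stronger inhibition), compound 1 `CSc1cc(C)c(C(=O)N=C(N)N)cc1S(C)(=O)=O` gives 6 nM, while compound 2 `Cc1cc(Sc2cccc(Cl)c2)c(S(C)(=O)=O)cc1C(=O)N=C(N)N` gives 37 nM, the higher of the two numbers; the single step of a 6.2-fold higher number from compound 1 to compound 2 (0.79 log units; beyond the scatter) separates them. Compound 3 `Cc1cc(-n2ccnc2)c(S(C)(=O)=O)cc1C(=O)N=C(N)N` differs from compound 2 by 1H-imidazol-1-yl in place of (3-chlorophenyl)sulfanyl on an aromatic carbon. Going by the values given here, only that one step bears on this change, and loosely, because a 6.2-fold higher number from compound 1 to compound 2 (0.79 log units; beyond the scatter) put 3-chlorophenyl in place of methyl on a sulfur, whereas here the whole (3-chlorophenyl)sulfanyl group leaves. A partial return toward the number of compound 1 seems most reasonable. Compound 3 is therefore estimated at 15 nM, within 4 nM to 60 nM. That estimate means an expected step of a 2.5-fold lower number from compound 2 to compound 3 (0.39 log units; beyond the scatter).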

Compound 3, half-maximal inhibitory concentration: 23 nM
For compound 3 the middle estimate is 1.5-fold (0.19 log units) below the measured one; the range from low to high includes it.
By their numbers in this assay, from the lowest: compound 1; then compounds 3 and 2 (each within the scatter of the next).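

In this assay, 1H-imidazol-1-yl and (3-chlorophenyl)sulfanyl on this aromatic carbon cannot be told apart, with a 1.6-fold lower number from compound 2 to compound 3 (0.21 log units; within the scatter). Two quite different ring-bearing groups are therefore tolerated about equally here, yet methylsulfanyl still gives the strongest inhibition of the three, with a 3.8-fold higher number from compound 1 to compound 3 (0.58 log units; beyond the scatter). Nothing shown here explains these numbers. Still open, going by these compounds, is whether an amine or a longer alkyl chain on this carbon would match methylsulfanyl, and whether an unsubstituted phenyl ring would behave like either ring-bearing group.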